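Aryl amide exchange ahead of a new potency reading

A few compounds are considered here, and "the series" means these few. Any claim that something is new, unique, unknown or untested is made for them only; others in the source may bear on it.

Measured so far in an assay on isolated protein for inhibition of Rho-associated protein kinase 2 (Homo sapiens), read by scintillation counting, radiometric assay and 33P incorporation, with a stated time of 40 min, in the presence of a further agent that is not named here; on this read-out lower numbers stand for stronger inhibition and higher numbers for weaker inhibition:
compound 1 `CN(C)c1ccc(C(=O)Nc2cccc(NC(=O)COc3ccc4c(c3)CCC(=O)N4)c2)cc1` gives 9970 nM
compound 2 `Cc1ccc(C(=O)Nc2cccc(NC(=O)COc3ccc4c(=O)ccoc4c3)c2)cc1` gives 22 nM

Compound 2 stands lowest of the two numbers; compound 1 is far higher, well beyond the usual scatter. Compound 3 `O=C(COc1ccc2c(=O)ccoc2c1)Nc1cccc(NC(=O)c2cnc(C(F)(F)F)s2)c1` is not yet measured in this assay. It differs from compound 2 by 2-(trifluoromethyl)-1,3-thiazol-5-yl in place of 4-methylphenyl on a carbonyl carbon. Going by the values given here, no single-place step between measured compounds guides this change, so the expectation is loose. The step from compound 2 to compound 3 is expected to be a mild weakening, possibly no more than the scatter, at a 2.0-fold higher number from compound 2 to compound 3 (0.31 log units; beyond the scatter). Compound 3 is thus estimated at 45 nM, within 10 nM to 250 nM.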

Compound 3, half-maximal inhibitory concentration: 10 nM
The estimate for compound 3 lay 4.5-fold (0.65 log units) above the measured number; the range from low to high includes it.
By their numbers in this assay, from the lowest: compound 3; then compound 2; then compound 1.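

The carbonyl carbon bearing the amide-type nitrogen does not need a six-membered aromatic ring of carbon only. In this assay, going by these compounds alone, a five-membered aromatic ring with 2 hetero atoms and a trifluoromethyl group is accepted there, with a modest gain beyond the scatter, a 2.2-fold lower number from compound 2 to compound 3 (0.34 log units; beyond the scatter), and this is the first single-place step. No measurement available bears on the reason for this step.

From the compounds shown here alone, it remains open whether the step belongs to the ring or to its trifluoromethyl group. A methyl group in place of that trifluoromethyl, or an amine at the same place on the ring, would help separate the two.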